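This account rests on a few compounds, and the source may have more. Where it says the series, first, only, none or still open, it means among the compounds named here.

Measured compounds:
compound 1 `NS(=O)(=O)CC(=O)NCCSc1nonc1/C(=N/O)Nc1cccc(Cl)c1` gives 1.26 h
compound 2 `NS(=O)(=O)CC(=O)NCCSc1nonc1/C(=N/O)Nc1ccc(F)c(C(F)F)c1` gives 1.07 h
compound 3 `NS(=O)(=O)CC(=O)NCCSc1nonc1/C(=N/O)Nc1ccc(F)c(Br)c1` gives 1.12 h

In an ADME assay on microsomes from liver (Mus musculus) for metabolic stability (a higher number here means that the compound lasts longer, a lower number that the compound disappears faster), the three numbers sit close together: compound 3 lies within the scatter of both neighbours, the gaps being a 1.1-fold lower number from compound 1 to compound 3 (0.05 log units; within the scatter) and a 1.0-fold higher number from compound 2 to compound 3 (0.02 log units; within the scatter). Compound 4 `N#Cc1cc(N/C(=N\O)c2nonc2SCCNC(=O)CS(N)(=O)=O)ccc1F` is not yet measured. The change from compound 3 is cyano in place of bromo on an aromatic carbon. Within the data shown here, the only step at the same aromatic carbon is a 1.0-fold higher number from compound 2 to compound 3 (0.02 log units; within the scatter), within the scatter, and the other changes on this ring, a 1.2-fold lower number from compound 1 to compound 2 (0.07 log units; within the scatter) and a 1.1-fold lower number from compound 1 to compound 3 (0.05 log units; within the scatter), are within the scatter too. Cyano does not occur among the measured compounds, so no step directly tests it. The expected step is therefore a 1.0-fold lower number from compound 3 to compound 4 (0.01 log units; within the scatter), nothing beyond the scatter. For compound 4 the estimate in this assay is 1.1 h, with a range from 0.6 h to 2.2 h.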

Compound 4, half-life: 2.38 h
For compound 4 the middle estimate is 2.2-fold (0.34 log units) below the measured one; measured number outside the range, above it.
By their numbers in this assay, from the lowest: compounds 2, 3, 1 and 4 (each within the scatter of the next, the first and the last beyond it).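

In this assay, the aromatic carbon ortho to a fluoro group turns out to be able to shift the half-life: cyano in place of bromo gives a 2.1-fold higher number from compound 3 to compound 4 (0.33 log units; beyond the scatter), and cyano in place of difluoromethyl gives a 2.2-fold higher number from compound 2 to compound 4 (0.35 log units; beyond the scatter). Bromo and difluoromethyl alone had not separated at this carbon. The change from 3-chlorophenyl to 3-cyano-4-fluorophenyl reads a 1.9-fold higher number from compound 1 to compound 4 (0.28 log units; within the scatter), so that pair remains unseparated.

From the compounds shown here alone, whether the shift is peculiar to cyano remains open, as an amide or a carboxylic acid at this carbon would test. Nothing available explains the cyano result.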